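Swapping bromo for methoxy on two related scaffolds

This account rests on a few compounds, and the source may have more. Where it says the series, first, only, none or still open, it means among the compounds named here.

Compound 1, `COc1cc(C=C(C(=O)/C=C/c2cccc(OC)c2OC)C(=O)/C=C/c2cccc(OC)c2OC)cc(Br)c1O`, was tested in a functional assay on SW480 cells (Homo sapiens) for antiproliferative activity, read by sulforhodamine B assay, with a stated time of 48 h (a lower number here means a stronger inhibitor, a higher number a weaker inhibitor), and gave 260 nM. Compound 2, `COc1cc(C=C(C(=O)/C=C/c2cccc(OC)c2OC)C(=O)/C=C/c2cccc(OC)c2OC)cc(OC)c1O`, differs from compound 1 by the change (methoxy in place of bromo on an aromatic carbon), and in this assay compound 2 gives 420 nM. That single change produced a 1.6-fold higher number from compound 1 to compound 2 (0.21 log units; within the scatter).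

Compound 3, `COc1cc(OC)c(/C=C/C(=O)C(=Cc2cc(Br)c(O)c(OC)c2)C(=O)/C=C/c2c(OC)cc(OC)cc2OC)c(OC)c1`, is built on a different core; the difference between the two cores is not broken down here. In this assay compound 3 gives 1450 nM, the highest number of the three measured compounds, and its values against compound 1 and compound 2 both lie beyond the scatter.

Compound 4, `COc1cc(OC)c(/C=C/C(=O)C(=Cc2cc(OC)c(O)c(OC)c2)C(=O)/C=C/c2c(OC)cc(OC)cc2OC)c(OC)c1`, has not yet been measured. It differs from compound 3 by methoxy in place of bromo on an aromatic carbon, the same change already seen between compound 1 and compound 2, at a place described in the same words. Because a 1.6-fold higher number from compound 1 to compound 2 (0.21 log units; within the scatter) stayed within the scatter, the step from compound 3 to compound 4 is expected to be similarly small, about a 1.6-fold higher number from compound 3 to compound 4 (0.20 log units; within the scatter). Compound 4 is therefore estimated at 2300 nM, with a likely range from 1100 nM to 4800 nM.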

Compound 4, half-maximal inhibitory concentration: 980 nM
Compound 4: the middle estimate sits 2.3-fold (0.37 log units) above what was measured; the whole stated range lies above it.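

In this assay, methoxy in place of bromo on the 4-hydroxy-3-methoxy-substituted ring gave a 1.5-fold lower number from compound 3 to compound 4 (0.17 log units; within the scatter), so on the core of compound 3, as on the core of compound 1, the swap does not move the number outside the usual scatter. Set side by side, the two steps cannot be told apart: the same change on two cores in this assay, a 1.6-fold higher number (0.21 log units; within the scatter) from compound 1 to compound 2 and a 1.5-fold lower number (0.17 log units; within the scatter) from compound 3 to compound 4, 2.4-fold (0.38 log units) apart, within the scatter of two such steps. This shows that in these two pairs the change carried over from one core to the other without a measurable effect, but it does not show a direction for the change on either core, and two pairs cannot vouch for other cores in this series.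

The compounds shown leave open whether a different group at this place, such as an amine, a carboxylic acid or a longer chain like propoxy, would shift the number beyond the scatter. They also leave open what replacing the hydroxy group, kept in all four compounds, would do.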